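The compounds below may be only part of what the source reports. "The series", "measured", "known", "first", "only" and "open" are said of these compounds alone.

Compound 1 `Oc1ccc(-c2cc(-c3cccc(Cl)c3)nc(-c3ccco3)c2)cc1` is a diaryl pyridine-type structure bearing a phenol, a 3-chlorophenyl group and a furan-2-yl group. In a functional assay on DU-145 cells (Homo sapiens) for cytotoxicity, read by CCK-8 assay and cell counting, with a stated time of 2 days (on this read-out lower numbers stand for stronger inhibition and higher numbers for weaker inhibition), compound 1 gives 5750 nM. Within the data shown here, its only measured neighbour is compound 2 `Oc1ccc(-c2cc(-c3ccc(Cl)cc3)nc(-c3ccco3)c2)cc1`, in which a 4-chlorophenyl group takes the place of the 3-chlorophenyl group; in this assay compound 2 gives 7280 nM. The step of a 1.3-fold higher number from compound 1 to compound 2 (0.10 log units; within the scatter) is within the scatter, so compound 1 stands as the lower of the two numbers without being separable from compound 2.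

Compound 3 `Oc1ccc(-c2cc(-c3ccccc3)nc(-c3cccc(Cl)c3)c2)cc1` is the compound that is not yet measured. It differs from compound 1 as follows: phenyl in place of furan-2-yl on an aromatic carbon. Among the measured compounds shown here, no measured step touches the furan-2-yl group, since the single step available concerns only the position of the chlorine on the other aryl ring and was within the scatter. There is thus no basis in the data for expecting a step beyond the scatter in either direction. The account therefore expects compound 3 to lie close to compound 1, with the expected step being a 1.2-fold lower number from compound 1 to compound 3 (0.06 log units; within the scatter). For compound 3 in this assay the expected value is 5000 nM, within a range from 1500 nM to 16000 nM.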

Compound 3, half-maximal inhibitory concentration: 5360 nM
Compound 3: middle estimate off by 1.1-fold (0.03 log units), on the low side, and the stated range covers the measured number.
By their numbers in this assay, from the lowest: compounds 3, 1 and 2 (each within the scatter of the next).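

Among these compounds, this step is the first to touch the position next to the ring nitrogen, which carries furan-2-yl in both compound 1 and compound 2. In this assay, phenyl in place of furan-2-yl gives a 1.1-fold lower number from compound 1 to compound 3 (0.03 log units; within the scatter), so on the core of compound 1 this position accepts a six-membered aromatic ring of carbon only in place of a five-membered aromatic ring with 1 hetero atom, with no change that can be told from the scatter. The furan oxygen, and with it the hydrogen-bond acceptor counted for furan-2-yl, is therefore not required to keep the number at this level in this pair. No measurement shown here bears on why the two groups read alike.

The compounds shown leave open whether the position would respond to something other than an aromatic ring, such as an amine, a carboxylic acid or a longer alkyl chain. They also leave open whether the same exchange reads alike with the 4-chlorophenyl group of compound 2 in place of the 3-chlorophenyl group.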